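The source may report more compounds than this note shows. Statements on the series, on what has been measured and on what is new or still open speak of the compounds shown alone.

Measured so far, with a functional assay on NT2 cells (Homo sapiens) for inhibition (on this read-out lower numbers stand for stronger inhibition and higher numbers for weaker inhibition), as the read-out:
compound 1 `CCC(C(=O)N[C@@H](CC(=O)O)C(=O)CSCc1ccccc1)n1ccnc(NCc2nc(C)no2)c1=O` gives 5.33 nM;
compound 2 `CCC(C(=O)N[C@@H](CC(=O)O)C(C)=O)n1cc(C(C)(C)C)nc(NCc2nonc2C)c1=O` gives 5.12 nM;
compound 3 `CCC(C(=O)N[C@@H](CC(=O)O)C(=O)CSCc1ccccc1)n1ccnc(NCc2cc(C)no2)c1=O` gives 6.41 nM.

Compound 3 carries the highest of the three numbers, yet its gaps to compound 1 and to compound 2 both sit within the scatter, so the three read as one level. Compound 4 `CCC(C(=O)N[C@@H](CC(=O)O)C(=O)CSCc1ccccc1)n1ccnc(NCc2cncs2)c1=O` differs from compound 3 by 1,3-thiazol-5-yl in place of 3-methyl-1,2-oxazol-5-yl on a saturated chain carbon bound to a nitrogen on an aromatic ring. Within the data shown here, the one measured step that bears on this place is a 1.2-fold higher number from compound 1 to compound 3 (0.08 log units; within the scatter), an exchange of one five-membered aromatic ring for another on the same saturated chain carbon, which left the number unmoved. On that basis the expectation for compound 4 in this assay is no step beyond the scatter, a 1.0-fold higher number from compound 3 to compound 4 (0.01 log units; within the scatter). Compound 4 is therefore estimated at 6.5 nM, with a range of 3 nM to 14 nM.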

Compound 4, half-maximal inhibitory concentration: 3.42 nM
Compound 4: the middle estimate sits 1.9-fold (0.28 log units) above what was measured; the measured number falls inside the stated range.
By their numbers in this assay, from the lowest: compounds 4, 2, 1 and 3 (each within the scatter of the next).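

At the saturated chain carbon bound to a nitrogen on an aromatic ring, 1,3-thiazol-5-yl brings sulfur into the group and drops the methyl, yet this assay shows a 1.9-fold lower number from compound 3 to compound 4 (0.27 log units; within the scatter) and a 1.6-fold lower number from compound 1 to compound 4 (0.19 log units; within the scatter). Three different five-membered aromatic rings at this place therefore read as one level, so the methyl is not needed to hold it. Nothing available explains why the number holds at this level. Still open, as far as these compounds go, is whether a six-membered pyridine ring, a plain alkyl chain or a carboxylic acid at this place would hold that level, and whether 1,3-thiazol-5-yl behaves the same on the core of compound 2.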